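Nitro for trifluoromethyl on two related anilinoquinazoline cores

A few compounds are considered here, and "the series" means these few. Any claim that something is new, unique, unknown or untested is made for them only; others in the source may bear on it.

Of the compounds shown here, three have been measured in a functional assay on MCF7 cells (Homo sapiens) for antiproliferative activity, read by MTT assay, with a stated time of 72 h; on this read-out higher numbers stand for weaker inhibition and lower numbers for stronger inhibition. Compound 1 `FC(F)(F)c1ccc(COc2cccc(Nc3ncnc4cc5c(cc34)OCCOCCOCCOCCO5)c2)cc1` gives 8480 nM. Compound 2 `FC(F)(F)c1ccc(COc2ccc(Nc3ncnc4cc5c(cc34)OCCOCCOCCOCCO5)cc2)cc1`, which is built from the same atoms joined differently, gives 10000 nM; the difference between the two cores is not broken down here. Compound 3 `O=[N+]([O-])c1ccc(COc2cccc(Nc3ncnc4cc5c(cc34)OCCOCCOCCOCCO5)c2)cc1` gives 6410 nM. All three numbers lie within the scatter of one another, so none of them can be set apart from the rest.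

Compound 3 arises from compound 1 by one change, (nitro in place of trifluoromethyl on an aromatic carbon), and that change produced a 1.3-fold lower number from compound 1 to compound 3 (0.12 log units; within the scatter). Compound 4 `O=[N+]([O-])c1ccc(COc2ccc(Nc3ncnc4cc5c(cc34)OCCOCCOCCOCCO5)cc2)cc1` has not yet been measured; it arises from compound 2 by the same change, (nitro in place of trifluoromethyl on an aromatic carbon), at a place described in identical words. The step from compound 2 to compound 4 in this assay is therefore expected to be small, estimated as a 1.3-fold lower number from compound 2 to compound 4 (0.11 log units; within the scatter), resting on the earlier step of a 1.3-fold lower number from compound 1 to compound 3 (0.12 log units; within the scatter). On that basis compound 4 is expected to give about 7700 nM, with a plausible range from 3500 nM to 17000 nM.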

Compound 4, half-maximal inhibitory concentration: > 100000 nM
Compound 4 gave a limit, no number; the forecaster's own chance of this, stated with the estimate: 20%; middle value at least 12-fold (1.11 log units) from the limit.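

In this assay, nitro in place of trifluoromethyl gave an at least 10-fold higher number from compound 2 to compound 4 (1.00 log units; beyond the scatter), so the change did not carry over from one core to the other: the same change on two cores in this assay, a 1.3-fold lower number (0.12 log units; within the scatter) from compound 1 to compound 3 and an at least 10-fold higher number (1.00 log units; beyond the scatter) from compound 2 to compound 4, at least 13-fold (1.12 log units) apart, beyond the scatter of two such steps

Compound 4 gives > 100000 nM, which is a limit of the assay and not a number, so the full size of this step remains unknown: the limit of > 100000 nM in this assay, at which 1 of the 4 values shown sits.

This shows that, in this assay, the result of the change on the core of compound 1 does not predict its result on the core of compound 2; it does not show why the two cores part, and one pair on each core sets no rule for other groups or other cores.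

As far as these compounds go, it remains open whether a different group in place of trifluoromethyl on the core of compound 2, such as a nitrile, an amine or a carboxylic acid, would read like compound 2 or like compound 4. From the compounds shown here alone, it also remains open whether those same groups would separate the two cores at all.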